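Methoxy for Methyl: Acid Dissociation of Compound 4

The source may hold more compounds than are shown below. What is called first, only, known or untested is meant among the compounds shown, and "the series" means these compounds.

Compound 1 `Cc1ncc([N+](=O)[O-])n1CC(O)Cn1cc(C(=O)O)c(=O)c2ccc(C(F)(F)F)cc21` gives 5.6 in a physicochemical assay for acid dissociation.
Compound 2 `Cc1ccc2c(c1)c(=O)c(C(=O)O)cn2CC(O)Cn1c([N+](=O)[O-])cnc1C` gives 6.43 in this assay.
Compound 3 `Cc1ncc([N+](=O)[O-])n1CC(O)Cn1cc(C(=O)O)c(=O)c2cccc(F)c21` gives 5.12 in this assay.

Among the three measured compounds, compound 2 stands highest in this assay. Its nearest neighbour is compound 1, whose number lies lower by a gap beyond the scatter, and the furthest is compound 3, whose number lies lower still, also beyond the scatter. Among the compounds with values here, the three compounds differ in more than one place, so no single step between them is isolated.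

Compound 4 `COc1ccc2c(c1)c(=O)c(C(=O)O)cn2CC(O)Cn1c([N+](=O)[O-])cnc1C` has not yet been measured. It differs from compound 2 in one place: methoxy in place of methyl on an aromatic carbon. Within the data shown here, no comparable step between measured compounds is available here, so the expectation rests only on the size of the change, a single heavy atom added on the carbocyclic ring, away from the carboxylic acid. The step is expected to be small, within the scatter or little beyond it, with no firm direction. For compound 4 the estimate in this assay is 6.3, with a range of 5.8 to 6.8. This expected estimate means a step of a number 0.13 log units lower from compound 2 to compound 4 (within the scatter).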

Compound 4, acid dissociation constant: 5.72
Compound 4: the middle estimate sits 0.58 log units above what was measured, and the stated range ends above it.
By their numbers in this assay, from the lowest: compound 3; then compounds 1 and 4 (each within the scatter of the next); then compound 2.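

Methoxy in place of methyl, on an aromatic carbon meta to a fused ring and para to a fused ring, is the first single change here that can be read on its own, and in this assay it gives a number 0.71 log units lower from compound 2 to compound 4 (beyond the scatter) for this exchange. The earlier compounds shown here differed in more than one place, so they could not show that this one substitution at this position is enough to move the number beyond the scatter. The data give no measured property that accounts for this step.

The compounds shown leave open whether another group at this carbon, such as an amine or a longer chain like ethoxy, would shift the number in the same direction. They also leave open whether the same exchange would give a similar step at another place on the ring or on a core carrying different substituents.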